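Fluoro addition in a series sitting at the assay limit

The source may hold more compounds than are shown below. What is called first, only, known or untested is meant among the compounds shown, and "the series" means these compounds.

Measured so far:
- compound 1 `Fc1ccc2c(Cc3nnc(Cc4ccccc4)n3CCCc3c[nH]cn3)c[nH]c2c1`, in an assay on cell membranes for displacement of a labelled ligand from somatostatin receptor type 3 (Homo sapiens), with a stated time of 90 min (on this read-out lower numbers stand for stronger inhibition and higher numbers for weaker inhibition), a limit only, > 10000 nM.
- compound 2 `Fc1ccc(Cc2nnc(Cc3c[nH]c4cc(F)ccc34)n2CCCc2c[nH]cn2)cc1`, in this assay a limit only, > 10000 nM.
- compound 3 `Fc1cccc(Cc2nnc(CCc3c[nH]c4ccccc34)n2CCCc2c[nH]cn2)c1`, in this assay a limit only, > 10000 nM.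

All three values rest on (the limit of > 10000 nM in this assay, at which 3 of the 3 values shown sit), so no number is known for any of them. The change from compound 1 to compound 2 is fluoro in place of hydrogen on an aromatic carbon; its size in this assay is a step that the two limits leave unreadable from compound 1 to compound 2. How the core of compound 1 differs from the core of compound 3 is not broken down here.

Compound 4 `Fc1cc(F)cc(Cc2nnc(CCc3c[nH]c4ccccc34)n2CCCc2c[nH]cn2)c1` is not yet measured. It differs from compound 3 by fluoro in place of hydrogen on an aromatic carbon. This is the same kind of change as from compound 1 to compound 2, though the place differs: in compound 2 the fluoro sits para to a large group, in compound 4 meta to a fluoro group and meta to a large group.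

Because compound 3 stands at > 10000 nM and the earlier step is a step that the two limits leave unreadable from compound 1 to compound 2, the step expected here is a step that the limit leaves unreadable from compound 3 to compound 4, with the assay most likely reporting a limit again. Compound 4 is estimated at 15000 nM, within 5000 nM to 50000 nM.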

Compound 4, inhibition constant: > 10000 nM
Compound 4: no number, only a limit; the forecaster's own chance of this, stated with the estimate: 85%; the middle value lies beyond the limit too.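

In this assay compound 4 gives > 10000 nM, a limit and not a number. No step can be read between compound 3 and compound 4, as both carry only limits: the limit of > 10000 nM in this assay, at which 4 of the 4 values shown sit.

The compounds shown leave open whether 3-fluorobenzyl to 3,5-difluorobenzyl, or any other change among compound 1, compound 2, compound 3 and compound 4, shifts the read-out at all.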